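This account rests on a few compounds, and the source may have more. Where it says the series, first, only, none or still open, it means among the compounds named here.

Compound 2 `CS(=O)(=O)Nc1ccc(O)c2c1CCCC2c1c[nH]cn1` is the weaker of the two compounds measured. In a functional assay on Urethra for agonist activity at Alpha-1A adrenergic receptor (Oryctolagus cuniculus) (a lower number here means a less potent compound, a higher number a more potent compound, by a factor of ten per unit of this negative logarithm), compound 2 gives 4.61, while compound 1 `CN(c1cccc2c1CCCC2c1c[nH]cn1)S(C)(=O)=O`, which shares the core but carries no hydroxy group and has a methyl on the sulfonamide nitrogen, gives 6.16, a gap beyond the scatter. Compound 3 `CS(=O)(=O)Nc1ccc(F)c2c1CCCC2c1c[nH]cn1` has not yet been measured. It differs from compound 2 in one place: fluoro in place of hydroxy on an aromatic carbon. For the measured compounds named here, no measured pair shows this exchange on its own, so the size of the step is uncertain. Since compound 1, lacking the hydroxy group, sits well above compound 2 in this assay, a step upward from compound 2 is expected for compound 3, though the methyl on the sulfonamide nitrogen also differs there. Compound 3 is estimated at 5.4, in the range 4.6 to 6.3, which is expected to mean a step of a number 0.79 log units higher from compound 2 to compound 3 (beyond the scatter).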

Compound 3, negative logarithm of the half-maximal effective concentration: 5.31
For compound 3 the middle estimate is 0.09 log units above the measured one, within the range that was stated.
By their numbers in this assay, from the lowest: compound 2; then compound 3; then compound 1.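

In this assay, the exchange at this position, para to a methanesulfonamido group, can now be read on its own: fluoro in place of hydroxy means a step of a number 0.70 log units higher from compound 2 to compound 3 (beyond the scatter), which the earlier pair could not show, as compound 1 and compound 2 differ in more than one place. The hydroxy group, with its hydrogen-bond donor, is thus not required at this place for the agonist response, and the compound with fluoro there is the more potent of the two. Nothing given here accounts for the size of this step.

The compounds shown do not separate losing the hydroxy group from gaining fluoro, and a plain hydrogen, a methoxy group, chloro or an amine at this place would be needed to do so. From the compounds shown here alone, what the methyl on the sulfonamide nitrogen contributes on its own also stays open.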